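A few compounds are considered here, and "the series" means these few. Any claim that something is new, unique, unknown or untested is made for them only; others in the source may bear on it.

In an ADME assay for permeability, with a stated time of 2 h (a higher number here means that the compound crosses the layer faster, a lower number that the compound crosses the layer more slowly), compound 1 (`Nc1cc(Oc2ccc(NC(=O)Nc3cccc(C(F)(F)F)c3)cc2)ncn1`) gives 245 nm/s and compound 2 (`CNc1cc(Oc2c(C)cc(NC(=O)Nc3cccc(C(F)(F)F)c3)cc2C)ncn1`) gives 295 nm/s within the scatter of it, which leaves compound 1 level with the only other measured point. Compound 3 (`O=C(Nc1ccc(Oc2cc(NCCO)ncn2)cc1)Nc1cccc(C(F)(F)F)c1`) carries the change 2-hydroxyethyl in place of hydrogen on a nitrogen on an aromatic ring on the core of compound 1: 2-hydroxyethyl in place of hydrogen on a nitrogen on an aromatic ring. Among the compounds with values here, no measured pair isolates this change. A modest downward step in this assay is expected, only just beyond the scatter. The estimated move is a 2.2-fold lower number from compound 1 to compound 3 (0.35 log units; beyond the scatter) on this reading. For compound 3 the expected value is 110 nm/s (45 nm/s to 250 nm/s).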

Compound 3, apparent permeability: 82 nm/s
For compound 3 the middle estimate is 1.3-fold (0.13 log units) above the measured one; low and high end bracket the measured number.
By their numbers in this assay, from the lowest: compound 3; then compounds 1 and 2 (each within the scatter of the next).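

Within the data shown here, the change of hydrogen to 2-hydroxyethyl on a nitrogen on an aromatic ring gives the first reading at this position: in this assay it gives a 3.0-fold lower number from compound 1 to compound 3 (0.48 log units; beyond the scatter) and so moves the number beyond the scatter. Compound 1 and compound 2 differ in more than one place and could not isolate any single change. No measured property bears on the reason for this step.

Open, as far as these compounds go, is whether the step follows the terminal hydroxyl or the chain itself, which an ethyl, a 2-methoxyethyl or a longer chain on the same nitrogen would separate. Also open, from the compounds shown here alone, is whether the step carries over to the core of compound 2.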